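Ester variation in the shared core series: working notes

The source may hold more compounds than are shown below. What is called first, only, known or untested is meant among the compounds shown, and "the series" means these compounds.

Two compounds have numbers in an assay on isolated protein for antagonist activity at Voltage-dependent L-type calcium channel subunit alpha-1C (Cavia porcellus), with a stated time of 15 min; on this read-out lower numbers stand for stronger inhibition and higher numbers for weaker inhibition. Compound 1 `CC1=C(C(=O)OC2CCCCC2)C(c2csc(-c3ccc(Cl)cc3)n2)C(C(=O)OC2CCCCC2)=C(C)N1` gives 11000 nM. Compound 2 `CC1=C(C(=O)OC(C)c2ccccc2)C(c2csc(-c3ccc(Cl)cc3)n2)C(C(=O)OC(C)c2ccccc2)=C(C)N1` gives 400000 nM, the higher of the two numbers, and its distance from compound 1 lies beyond the scatter. Compound 3 `CCOC(=O)C1=C(C)NC(C)=C(C(=O)OC(C)c2ccccc2)C1c1csc(-c2ccc(Cl)cc2)n1` is not yet measured; it differs from compound 2 in one place: hydrogen in place of phenyl on a saturated chain carbon bound to an oxygen next to a carbonyl group and a saturated chain carbon. Among the measured compounds shown here, no measured step of this kind is available to set the size, but a move toward lower numbers is expected, and the step of a 10-fold lower number from compound 2 to compound 3 (1.00 log units; beyond the scatter) is estimated to lie beyond the scatter. Compound 3 is expected to give 40000 nM, within 8000 nM to 200000 nM.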

Compound 3, half-maximal inhibitory concentration: 13800 nM
Compound 3: the middle estimate sits 2.9-fold (0.46 log units) above what was measured; low and high end bracket the measured number.
By their numbers in this assay, from the lowest: compounds 1 and 3 (each within the scatter of the next); then compound 2.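

In this assay, replacing 1-phenylethyl with ethyl on one ester gives a 29-fold lower number from compound 2 to compound 3 (1.46 log units; beyond the scatter) and marks this position as sensitive to the change, with the step large and beyond the scatter. The other ester of compound 3 still carries 1-phenylethyl, so the step was read with that group unchanged. Nothing available accounts for the size of the step.

Going by these compounds, whether the same change at the second 1-phenylethyl ester would give a step of similar size remains open. Also open, on these data alone, is how a longer chain such as butyl, or an aminoethyl group, would read at this position.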